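Removing the Nitro Group from a Weak Sulfonamide Inhibitor

The source may hold more compounds than are shown below. What is called first, only, known or untested is meant among the compounds shown, and "the series" means these compounds.

Going by the values given here, compound 2 `CC(=O)c1ccc(NC(=O)C2CCCN2S(=O)(=O)c2ccc([N+](=O)[O-])cc2)cc1` has the higher of the two numbers measured so far: in a functional assay, read by spectrophotometry, with a stated time of 20 min (a higher number here means a weaker inhibitor, a lower number a stronger inhibitor), compound 2 gives 19000000 nM. Among the compounds with values here, its one measured neighbour, compound 1 `CC(=O)c1ccc(NC(=O)C2CC(O)CN2S(=O)(=O)c2ccc([N+](=O)[O-])cc2)cc1`, gives 7100000 nM in this assay, and the step of a 2.7-fold higher number from compound 1 to compound 2 (0.43 log units; beyond the scatter) is the only measured step available. Compound 3 `CC(=O)c1ccc(NC(=O)C2CCCN2S(=O)(=O)c2ccccc2)cc1` differs from compound 2 in one place: hydrogen in place of nitro on an aromatic carbon. Within the data shown here, no measured step bears on this change, since the single known step involved the hydroxy group on the saturated ring rather than the nitro group on the aromatic ring. With nothing measured pointing to a direction, the expected step of a 1.1-fold higher number from compound 2 to compound 3 (0.02 log units; within the scatter) is a small one, quite possibly within the scatter. Compound 3 is therefore estimated to give about 20000000 nM in this assay, with a range from 6000000 nM to 70000000 nM.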

Compound 3, half-maximal inhibitory concentration: 69000000 nM
Estimate against measurement, compound 3: 3.5-fold (0.54 log units) below; the measured number falls inside the stated range.
By their numbers in this assay, from the lowest: compound 1; then compound 2; then compound 3.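

In this assay, replacing 4-nitrophenyl with phenyl gives a 3.6-fold higher number from compound 2 to compound 3 (0.56 log units; beyond the scatter), so at this place on the aromatic ring, nitro goes with a stronger inhibitor than hydrogen does. Going by these compounds alone, the earlier step, a 2.7-fold higher number from compound 1 to compound 2 (0.43 log units; beyond the scatter), concerned only the hydroxy group on the saturated ring, so this is the first measured sign that the aromatic ring's substituent also affects the number, and here too hydrogen gives the weaker inhibitor. No measurement shown explains this step.

The compounds shown carry only nitro or hydrogen at this place, so it remains open how an amine, a nitrile or a methoxy group there would compare. On these data alone, it is also open whether losing the nitro group would produce a step of similar size with the hydroxy group of compound 1 in place.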